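Working notes: amine variation at the thiocarbonyl carbon

A few compounds are considered here, and "the series" means these few. Any claim that something is new, unique, unknown or untested is made for them only; others in the source may bear on it.

Measured in a functional assay on MGC-803 cells (Homo sapiens) for antiproliferative activity, read by CCK-8 assay, with a stated time of 72 h, tested at 2 uM (a higher number here means a stronger effect of the compound at the concentration tested, a lower number a weaker effect), so far:
- compound 1 `Nc1ccccc1NC(=O)c1ccc(CSC(=S)N2CCCc3ccccc32)cc1` gives 38.5%
- compound 2 `Nc1ccccc1NC(=O)c1ccc(CSC(=S)N2CCN(c3ccc(F)cc3)CC2)cc1` gives 18.8%
- compound 3 `CCN(Cc1ccncc1)C(=S)SCc1ccc(C(=O)Nc2ccccc2N)cc1` gives 71.6%

Compound 2 stands lowest of the three in this assay; compound 1 is the nearest to it and compound 3 the furthest, both separations beyond the scatter. Going by the values given here, the one step that can be read as a single change is a number 33.1 percentage points higher from compound 1 to compound 3 (beyond the scatter), a large rise that exchanges the whole amine on the thiocarbonyl carbon.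

Compound 4 `Nc1ccccc1NC(=O)c1ccc(CSC(=S)N2CCN(C3CCCCC3)CC2)cc1` is not yet measured. It differs from compound 2 by cyclohexyl in place of 4-fluorophenyl on an amine nitrogen in a ring. Among the compounds with values here, no measured pair alters only a group on the ring nitrogen of that six-membered non-aromatic ring with 2 nitrogen, so the step from compound 1 to compound 3 offers no direct guide here, and no direction can be argued from the data. The expectation is therefore a step of a number 5.2 percentage points higher from compound 2 to compound 4 (within the scatter), that is, none beyond the scatter, with a wide range. Compound 4 is estimated at 24%, between 5% and 50%.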

Compound 4, a percentage reported as inhibition, at one concentration (the size of the read-out at that concentration, not a potency): 16.9%
For compound 4 the middle estimate is 7.1 percentage points above the measured one; the range from low to high includes it.
By their numbers in this assay, from the lowest: compounds 4 and 2 (each within the scatter of the next); then compound 1; then compound 3.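

In this assay the exchange of 4-fluorophenyl for cyclohexyl on the amine nitrogen in the ring gives a number 1.9 percentage points lower from compound 2 to compound 4 (within the scatter) and so does not separate the two compounds. Going by these compounds alone, this is the first reading at this position, and at this position an aromatic ring of carbon only and a non-aromatic ring of carbon only cannot be told apart in this pair. No supporting measurement is available to account for this result.

From the compounds shown here alone, whether a methyl or acetyl group, or a plain hydrogen, on that ring nitrogen would read differently remains open. Also open, going by these compounds, is whether any group at this position can shift the read-out beyond the scatter, or whether the six-membered non-aromatic ring with 2 nitrogen itself sets the level.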